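The source may hold more compounds than are shown below. What is called first, only, known or untested is meant among the compounds shown, and "the series" means these compounds.

Of the compounds shown here, two have so far been measured in a functional assay on KB cells (Homo sapiens) for inhibition; on this read-out lower numbers stand for stronger inhibition of growth and higher numbers for weaker inhibition of growth. Compound 1, `Cc1cccc2sc(NC(=O)COc3ccc(/C=C4\SC(=O)NC4=O)cc3)nc12`, returns only a limit in this assay, > 100000 nM, and not a number. Compound 2, `Cc1cccc(NC(=O)COc2ccc(/C=C3\SC(=O)NC3=O)cc2)n1`, gives 75000 nM in this assay. Within the data shown here, compound 2 thus holds the only number seen so far, while the other result sits at the limit of > 100000 nM in this assay, at which 1 of the 2 values shown sits. Among the measured compounds shown here, no step between two measured compounds can be drawn, so nothing yet shows how a change in the part that hangs on the amide-type nitrogen moves growth inhibition. Compound 3, `O=C(COc1ccc(/C=C2\SC(=O)NC2=O)cc1)Nc1ccc([N+](=O)[O-])cc1`, is not yet measured. It differs from compound 2 in one place: 4-nitrophenyl in place of 6-methylpyridin-2-yl on an amide-type nitrogen. With only two weak results to go on, the expected step from compound 2 to compound 3, a 1.1-fold lower number from compound 2 to compound 3 (0.03 log units; within the scatter), is none beyond the scatter in this assay, in either direction. Compound 3 is therefore expected to give about 70000 nM in this assay, within a range from 20000 nM to 250000 nM, with a fair chance that only a limit is reported.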

Compound 3, concentration for 50% growth inhibition: > 100000 nM
Compound 3: no number, only a limit; the forecaster's own chance of this, stated with the estimate: 40%; middle value at least 1.4-fold (0.15 log units) from the limit.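

In this assay compound 3 returns only a limit and not a number, > 100000 nM. Placing 4-nitrophenyl in place of 6-methylpyridin-2-yl on the amide-type nitrogen gives the first step that can be drawn in this series, an at least 1.3-fold higher number from compound 2 to compound 3 (0.12 log units; that floor lies within the scatter), so this change shows no sign of stronger inhibition of growth, although only a floor for the step can be stated and its true size stays unknown. With this result, most of the series now rests on a limit and not on a number, which leaves compound 2 as the only compound with a measured value: the limit of > 100000 nM in this assay, at which 2 of the 3 values shown sit.

Going by these compounds, what remains open is whether any group on this amide-type nitrogen can bring growth inhibition clearly beyond that of compound 2, and the two aromatic groups compared here cannot settle this. A plain phenyl, a 4-aminophenyl, a 4-carboxyphenyl or a longer alkyl chain in this place would show whether the position can move the read-out at all, and whether a real number can be obtained there.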